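The compounds below may be only part of what the source reports. "The series", "measured", "known", "first", "only" and "open" are said of these compounds alone.

Measured in an assay on CHO cells for displacement of a labelled ligand from adenosine receptor A3 (Homo sapiens), read by scintillation counting, with a stated time of 120 min; on this read-out lower numbers stand for stronger inhibition and higher numbers for weaker inhibition:

Compound 1 `COc1cccc(CNc2nc(N)c3nc(-c4ccc(C)o4)sc3n2)c1`: 160 nM
Compound 2 `Cc1ccc(-c2nc3c(N)nc(NCc4cccs4)nc3s2)o1`: 15.3 nM
Compound 3 `Nc1nc(NCc2ccncc2)nc2sc(-c3ccco3)nc12`: 827 nM

Compound 3 stands at the highest number of the three in this assay. Compound 1 is nearest to it, and compound 2 is furthest, both with lower numbers than compound 3 and both gaps beyond the scatter.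

The step to compound 4 `Nc1nc(NCc2ccccn2)nc2sc(-c3ccco3)nc12` is the change (pyridin-2-yl in place of pyridin-4-yl on a saturated chain carbon bound to a nitrogen on an aromatic ring). Among the compounds with values here, the one measured step at this position is a 10-fold lower number from compound 1 to compound 2 (1.02 log units; beyond the scatter), a large step, but it exchanges the whole aromatic group for a different one, whereas the present change keeps the same atoms and only joins them differently. Within the data shown here, no measured pair shows a ring-nitrogen shift of this kind, so the size of the effect in this assay is not anchored by the data. A modest step is expected, with direction uncertain; the estimated step is a 1.7-fold lower number from compound 3 to compound 4 (0.22 log units; within the scatter). Compound 4 is therefore expected to give about 500 nM, within the range 150 nM to 1800 nM.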

Compound 4, inhibition constant: 59 nM
Estimate against measurement, compound 4: 8.5-fold (0.93 log units) above; measured number outside the range, below it.
By their numbers in this assay, from the lowest: compound 2; then compound 4; then compound 1; then compound 3.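

In this assay, rearranging the atoms of the pyridine ring alone gives a 14-fold lower number from compound 3 to compound 4 (1.15 log units; beyond the scatter), so this place on the chain carbon responds strongly to where the ring nitrogen lies, not only to which aromatic group is present. The earlier step at this place, a 10-fold lower number from compound 1 to compound 2 (1.02 log units; beyond the scatter), exchanged one aromatic group for a different one, whereas here both groups have the same counts of heavy atoms, hydrogen-bond donors and acceptors, yet the step is also large. Nothing available accounts for the difference between pyridin-2-yl and pyridin-4-yl.

Where pyridin-3-yl on the same chain carbon would fall remains open. Also open, on these data alone, is whether pyridin-2-yl in place of pyridin-4-yl gives a step of similar size on the core of compound 1, or with a longer chain to the ring.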